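This account rests on a few compounds, and the source may have more. Where it says the series, first, only, none or still open, it means among the compounds named here.

Measured compounds:
compound 1 `O=C(Nc1ccc2cccnc2c1)c1ccc(Cl)nc1` — < 6.7 (a limit of the assay, not a number)
compound 2 `Cc1nc(-c2ccc(F)cc2)ccc1C(=O)Nc1ccc2ncsc2c1` — 6.7
compound 3 `Cc1nc(-c2ccc(F)cc2)ccc1C(=O)Nc1ccc2scnc2c1` — 7.5

In an in vitro functional assay on 1321-N1 cells for antagonist activity at transient receptor potential cation channel subfamily V member 1 (Homo sapiens), read by FLIPR and calcium flux (a lower number here means a less potent compound, a higher number a more potent compound, by a factor of ten per unit of this negative logarithm), compound 3 gives 7.5, the highest of the two numbers in the set. Compound 2 shares the amide and the fluorophenyl-bearing pyridine with compound 3 but carries its fused bicyclic amine in a differently arranged form; compound 2 gives 6.7, a value that lies lower than that of compound 3 by a gap beyond the usual scatter. For compound 1 only a limit is reported, < 6.7, and it is the limit of < 6.7 in this assay, at which 1 of the 3 values shown sits; it gives no number to compare against.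

Compound 4 `Cc1nc(-c2ccc(F)cc2)ccc1C(=O)Nc1ccc2sc(CN(C)C)nc2c1` is the next entry. Relative to compound 3 it shows ((dimethylamino)methyl in place of hydrogen on an aromatic carbon). Among the measured compounds shown here, no measured pair covers a change of this kind, so nothing here calibrates it. The step of a number 0.20 log units lower from compound 3 to compound 4 (within the scatter) is expected to stay within the scatter, with a slight lean toward loss. On that basis compound 4 is estimated at 7.3 in this assay, within a range from 6.6 to 8.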

Compound 4, negative logarithm of the antagonist equilibrium constant: < 6.7
Compound 4 was reported as a limit; the forecaster's own chance of this, stated with the estimate: 10%; middle value at least 0.60 log units away from the limit.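

Up to compound 3, this carbon of the five-membered aromatic ring, next to the ring nitrogen and the ring sulfur, carried only hydrogen, so nothing yet showed how the series answers to a substituent there. In this assay, (dimethylamino)methyl in place of that hydrogen gives a number at least 0.80 log units lower from compound 3 to compound 4 (beyond the scatter), so this position does not accept every substituent without loss. Compound 4 is reported only as a limit, which it shares with compound 1: the limit of < 6.7 in this assay, at which 2 of the 4 values shown sit.

The compounds shown leave open whether the loss follows the dimethylamino nitrogen or any added carbon at this place; a plain methyl group or a methoxymethyl chain would separate the two. From the compounds shown here alone, the true value of compound 4 also stays open, and with it the full size of the step.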